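This account rests on a few compounds, and the source may have more. Where it says the series, first, only, none or still open, it means among the compounds named here.

For the measured compounds named here, in a functional assay on the whole organism (strain Kunming) with Mus musculus as the target, with a stated time of 0.5 h (on this read-out higher numbers stand for an effect only at larger amounts of compound and lower numbers for an effect already at smaller amounts), compound 3 `COc1cc(OC)c(OC)cc1/C=C/COC(=O)/C=C/c1cccc(Br)c1` gives 215 mg/kg, the only actual number in this small series. Compound 1 `COc1ccccc1/C=C/C(=O)OC/C=C/c1cc(OC)c(OC)cc1OC` reads > 300 mg/kg, which is a limit and not a number. Compound 2 `COc1cc(OC)c(OC)cc1/C=C/COC(=O)/C=C/c1ccc(OC)c(OC)c1` reads > 300 mg/kg, which is also a limit.

Compound 4 `COc1cc(OC)c(OC)cc1/C=C/COC(=O)/C=C/c1ccccc1Cl` has not yet been measured. Its difference from compound 3 is 2-chlorophenyl in place of 3-bromophenyl on a double-bonded chain carbon bound to a double-bonded chain carbon, with 2-chlorophenyl in place of 3-bromophenyl on a double-bonded chain carbon bound to a double-bonded chain carbon.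

Two measured steps change this same place: an at least 1.3-fold lower number from compound 1 to compound 3 (0.14 log units; that floor lies within the scatter), and an at least 1.3-fold lower number from compound 2 to compound 3 (0.14 log units; that floor lies within the scatter). Both are floors only, and both lie within the scatter. The third step, a step that the two limits leave unreadable from compound 1 to compound 2, gives no size to work from. Going by the values given here, no measured step covers the exchange of 3-bromophenyl for 2-chlorophenyl.

No step beyond the scatter is therefore expected in this assay, and no direction can be assigned. The expected change is a 1.1-fold higher number from compound 3 to compound 4 (0.05 log units; within the scatter). A reading that stops at the limit remains possible because of the limit of > 300 mg/kg in this assay, at which 2 of the 3 values shown sit. For compound 4 the estimated value is 240 mg/kg, with an expected range of 125 mg/kg to 450 mg/kg.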

Compound 4, dose for half-maximal effect: 248 mg/kg
Compound 4: the middle estimate sits 1.0-fold (0.01 log units) below what was measured; low and high end bracket the measured number.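

In this assay, the exchange of 3-bromophenyl for 2-chlorophenyl gives a 1.2-fold higher number from compound 3 to compound 4 (0.06 log units; within the scatter), so this position now holds two different halogen-bearing phenyl groups with actual numbers that cannot be told apart. Against the methoxy-bearing compounds, the series shows an at least 1.2-fold lower number from compound 2 to compound 4 (0.08 log units; that floor lies within the scatter) and an at least 1.2-fold lower number from compound 1 to compound 4 (0.08 log units; that floor lies within the scatter); both are floors within the scatter, so neither establishes a real separation, although among the four compounds shown the two with a halogen give numbers and the two with only methoxy groups on this ring give limits, with no compound going against that split. The true size of these steps stays hidden, and the step between compound 1 and compound 2 cannot be read, because of this: the limit of > 300 mg/kg in this assay, at which 2 of the 4 values shown sit.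

The compounds shown leave open whether the halogen itself matters at this position, since the change of halogen and the change of its place on the ring arrive together in the step to compound 4. They also leave open how an amine or a carboxylic acid in place of the chloro would read in this assay.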